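A few compounds are considered here, and "the series" means these few. Any claim that something is new, unique, unknown or untested is made for them only; others in the source may bear on it.

Measured in a functional assay on SGC-7901 cells (Homo sapiens) for cytotoxicity, read by MTT assay, with a stated time of 38 h; a higher number here means a weaker inhibitor, a lower number a stronger inhibitor:
- compound 1 `COc1cc(OC)c2c(=O)c(OCCCCN3CCCC3)c(-c3cc(OC)c(OC)c(OC)c3)oc2c1`: 26800 nM
- compound 2 `COc1cc(OC)c2c(=O)c(OCCCCN3CCCCC3)c(-c3cc(OC)c(OC)c(OC)c3)oc2c1`: 6080 nM

Compound 2 has the lower of the two numbers, which makes it the stronger inhibitor of this pair. The next compound to consider, compound 3 `COc1cc(OC)c2c(=O)c(OCC(=O)N/N=C/c3ccc[nH]3)c(-c3cc(OC)c(OC)c(OC)c3)oc2c1`, has not yet been measured. The change leading to it is a group of 10 heavy atoms (6 carbon, 3 nitrogen, 1 oxygen; one five-membered aromatic ring with 1 hetero atom) in place of a group of 9 heavy atoms (8 carbon, 1 nitrogen; one six-membered non-aromatic ring with 1 hetero atom), on a saturated chain carbon bound to an oxygen on an aromatic ring. The 3-(piperidin-1-yl)propyl group leaves, and with it the six-membered non-aromatic ring. A group with a five-membered aromatic ring enters at the same place.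

Among the measured compounds shown here, only one measured step offers any guide: a 4.4-fold lower number from compound 1 to compound 2 (0.64 log units; beyond the scatter). That step swapped one ring for another, yet it still moved the number beyond the scatter. The change to compound 3 replaces a whole group, so a step of similar or larger size would not be surprising. The data do not settle its direction. For the measured compounds named here, compound 2, at 6080 nM, holds the best number so far, so a higher number is the more likely expectation, though only weakly supported. The expected change is a 2.5-fold higher number from compound 2 to compound 3 (0.39 log units; beyond the scatter). For compound 3 the estimated value is 15000 nM, with an expected range from 3000 nM to 60000 nM.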

Compound 3, half-maximal inhibitory concentration: 8730 nM
Compound 3: the middle estimate sits 1.7-fold (0.24 log units) above what was measured, within the range that was stated.
By their numbers in this assay, from the lowest: compounds 2 and 3 (each within the scatter of the next); then compound 1.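

In this assay, the step of a 1.4-fold higher number from compound 2 to compound 3 (0.16 log units; within the scatter) shows that this place, on a saturated chain carbon bound to an oxygen on an aromatic ring, can take a very different group with no change that stands out from the scatter. The 3-(piperidin-1-yl)propyl group and its six-membered non-aromatic ring leave, and a group with a five-membered aromatic ring and double bonds outside that ring enters, so among these compounds a number at this level does not depend on the piperidine. The same entering group also gives a 3.1-fold lower number from compound 1 to compound 3 (0.49 log units; beyond the scatter), which leaves compound 1, with its pyrrolidin-1-yl group, as the one that stands apart, though no measurement here explains any of these numbers.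

As far as these compounds go, what remains open is which part of the entering group matters: its five-membered aromatic ring, or the chain that carries that ring. A phenyl ring in place of the five-membered aromatic ring, or a morpholine or a carboxylic acid at the end of the chain, would help to separate these parts.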